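The source may report more compounds than this note shows. Statements on the series, on what has been measured and on what is new or still open speak of the compounds shown alone.

Measured compounds in a functional assay on NCI-H460 cells (Homo sapiens) for cytotoxicity, read by MTT assay, with a stated time of 48 h; on this read-out higher numbers stand for weaker inhibition and lower numbers for stronger inhibition:
- compound 1 `C=C1C(=O)O[C@H]2CC3=C[C@H](C/C(C)=C/[C@@H](OC(=O)c4ccc(C(F)(F)F)cc4)[C@H]12)OC3=O` reaches only the limit of the assay, > 10000 nM
- compound 2 `C=C1C(=O)O[C@H]2CC3=C[C@H](C/C(C)=C/[C@@H](OC(=O)c4ccc(C(C)=O)cc4)[C@H]12)OC3=O` gives 2200 nM
- compound 3 `C=C1C(=O)O[C@H]2CC3=C[C@H](C/C(C)=C/[C@@H](OC(=O)CCCCC)[C@H]12)OC3=O` gives 5900 nM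

Compound 1 stands at the weak end of this small set; its result is a limit rather than a number, so only a floor for its distance from the others can be stated. The compound to be judged is compound 4 `C=C1C(=O)O[C@H]2CC3=C[C@H](C/C(C)=C/[C@@H](OC(=O)/C=C/c4ccncc4)[C@H]12)OC3=O`, which differs from compound 1 in one place: 2-(pyridin-4-yl)ethenyl in place of 4-(trifluoromethyl)phenyl on a carbonyl carbon.

Two measured steps start from compound 1 and both change the same ester end of the shared core. an at least 4.5-fold lower number from compound 1 to compound 2 (0.65 log units; beyond the scatter). an at least 1.6-fold lower number from compound 1 to compound 3 (0.22 log units; that floor lies within the scatter). Going by these compounds, both replacements of the 4-(trifluoromethyl)phenyl arrangement thus gave lower numbers, though the exact size of each step is unknown because compound 1 sits at the limit of > 10000 nM in this assay, at which 1 of the 3 values shown sits. Within the data shown here, a step of similar kind, towards a lower number, is therefore expected for compound 4, though the new 2-(pyridin-4-yl)ethenyl group has no measured counterpart here and the estimate is correspondingly broad. Compound 4 is estimated at 3500 nM, between 1200 nM and 10000 nM, which means an expected step of an at least 2.8-fold lower number from compound 1 to compound 4 (0.45 log units; beyond the scatter).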

Compound 4, half-maximal inhibitory concentration: 2100 nM
The estimate for compound 4 lay 1.7-fold (0.22 log units) above the measured number, and the stated range covers the measured number.
By their numbers in this assay, from the lowest: compounds 4 and 2 (each within the scatter of the next); then compound 3. At a limit, above all of these: compound 1.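

Putting 2-(pyridin-4-yl)ethenyl on the carbonyl carbon in this assay gives an at least 4.7-fold lower number from compound 1 to compound 4 (0.67 log units; beyond the scatter), but the starting point of that step is a limit, so its size is only a floor: the limit of > 10000 nM in this assay, at which 1 of the 4 values shown sits. The new group also improves on the pentyl chain, with a 2.8-fold lower number from compound 3 to compound 4 (0.45 log units; beyond the scatter), so a second group besides 4-acetylphenyl now gives a lower number than pentyl at this place. Against 4-acetylphenyl there is a 1.0-fold lower number from compound 2 to compound 4 (0.02 log units; within the scatter), so these two different groups cannot be told apart here.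

The compounds shown do not separate the part played by the ring nitrogen from that of the double bond, as 2-phenylethenyl or a pyridin-4-yl group set directly on the carbonyl carbon could. Going by these compounds, whether an amine or a carboxylic acid on the ring would change the number also remains open.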